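Cytotoxicity of an N-oxide tetracycle with a swapped side chain

The source may hold more compounds than are shown below. What is called first, only, known or untested is meant among the compounds shown, and "the series" means these compounds.

Compounds measured in a toxicity assay on HEK-293T cells (Homo sapiens) for cytotoxicity, read by MTT assay, with a stated time of 72 h (on this read-out higher numbers stand for weaker inhibition and lower numbers for stronger inhibition), so far:
compound 1 `O=C1c2c[n+]([O-])c3ccccc3c2C(=O)c2c1c1ccccc1n2Cc1cn([C@H]2O[C@H](CO)[C@@H](O)[C@H]2O)nn1` gives 1370 nM
compound 2 `CN1CCN(CCCCn2c3c(c4ccccc42)C(=O)c2c[n+]([O-])c4ccccc4c2C3=O)CC1` gives 100 nM

Compound 2 stands lowest of the two numbers measured; compound 1 gives the nearest value, and that gap lies beyond the scatter. Compound 3 `O=C1c2c[n+]([O-])c3ccccc3c2C(=O)c2c1c1ccccc1n2Cc1cn(C[C@@H](O)CO)nn1` is not yet measured. It differs from compound 2 by 1-(2,3-dihydroxypropyl)-1H-1,2,3-triazol-4-yl in place of 3-(4-methylpiperazin-1-yl)propyl on a saturated chain carbon bound to an aromatic nitrogen. Because compound 1 gives 1370 nM with a triazole on the same chain carbon, compound 3 is expected to move back toward that number, by a step of a 9.0-fold higher number from compound 2 to compound 3 (0.95 log units; beyond the scatter) from compound 2. In this assay compound 3 is therefore estimated at 900 nM, within 300 nM to 3000 nM.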

Compound 3, half-maximal inhibitory concentration: 2030 nM
Estimate against measurement, compound 3: 2.3-fold (0.35 log units) below; measured number inside the range.
By their numbers in this assay, from the lowest: compound 2; then compounds 1 and 3 (each within the scatter of the next).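

In this assay, the swap of 3-(4-methylpiperazin-1-yl)propyl for 1-(2,3-dihydroxypropyl)-1H-1,2,3-triazol-4-yl on a saturated chain carbon bound to an aromatic nitrogen gives a 20-fold higher number from compound 2 to compound 3 (1.31 log units; beyond the scatter), so the number at this position responds strongly to this change. With the triazole kept, 2,3-dihydroxypropyl in place of 3,4-dihydroxy-5-(hydroxymethyl)oxolan-2-yl on an aromatic nitrogen gives a 1.5-fold higher number from compound 1 to compound 3 (0.17 log units; within the scatter), so these two compounds cannot be told apart. Nothing measured here accounts for either step.

From the compounds shown here alone, the ring and the chain change together in the large step, and which of them carries it stays open. A morpholine or a dimethylamine at the end of the same butyl chain could separate the two.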